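Substituent swap on the aromatic carbon of compound 2

The source may report more compounds than this note shows. Statements on the series, on what has been measured and on what is new or still open speak of the compounds shown alone.

Compound 2 `Cc1c(C2NS(=O)(=O)c3ccccc32)c2cc(F)ccc2n1CC(=O)O` gives 430 nM in an assay on cells for binding affinity to prostaglandin D2 receptor 2 (Homo sapiens), read by radioligand binding; a lower number here means a stronger inhibitor, a higher number a weaker inhibitor. Among the two compounds measured this is the lower of the two numbers, but the nearest neighbour, compound 1 `Cc1c(C2NS(=O)(=O)c3ccccc32)c2cc(Cl)ccc2n1CC(=O)O`, gives 690 nM in this assay, and the only measured step, a 1.6-fold lower number from compound 1 to compound 2 (0.21 log units; within the scatter), lies within the scatter. The two values are therefore read as indistinguishable, and nothing in the series yet shows a change at this place that moves the number beyond the scatter.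

Compound 3 `Cc1ccc2c(c1)c(C1NS(=O)(=O)c3ccccc31)c(C)n2CC(=O)O` has not been measured in this assay. It differs from compound 2 by methyl in place of fluoro on an aromatic carbon. For the measured compounds named here, the single step that bears on this exchange is the fluoro in place of chloro on an aromatic carbon, a 1.6-fold lower number from compound 1 to compound 2 (0.21 log units; within the scatter), which stayed within the scatter. A methyl at this place is therefore expected to give no step beyond the scatter in this assay, in either direction. For compound 3 the expected step is a 1.2-fold higher number from compound 2 to compound 3 (0.07 log units; within the scatter). For compound 3 the estimate in this assay is 500 nM, with an expected range from 200 nM to 1300 nM.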

Compound 3, inhibition constant: 1500 nM
Beside the measured number, compound 3's estimate is 3.0-fold (0.48 log units) below it; the measured number lies above the stated range.
By their numbers in this assay, from the lowest: compounds 2 and 1 (each within the scatter of the next); then compound 3.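

In this assay, this position now shows that the group on it can matter: methyl in place of fluoro gives a 3.5-fold higher number from compound 2 to compound 3 (0.54 log units; beyond the scatter), and methyl in place of chloro gives a 2.2-fold higher number from compound 1 to compound 3 (0.34 log units; beyond the scatter). Both steps are modest, but both lie beyond the scatter, whereas the exchange between the two halogens stayed within it, so compound 3 is the weakest of the three and the aromatic carbon, meta to a fused ring and para to a fused ring, is not indifferent to its substituent. The data offer no measurement that could explain why methyl separates from fluoro and chloro here.

For the compounds shown here, with only three groups at this one place, it remains open whether the higher number belongs to methyl alone or extends to other groups, such as a methoxy, an amine or a longer alkyl chain. Also open, as far as these compounds go, is how the unsubstituted carbon, bearing only hydrogen, compares with these three, and whether the same exchange on another carbon of this ring would give a step of similar size.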